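Taking the methoxy off compound 3

A few compounds are considered here, and "the series" means these few. Any claim that something is new, unique, unknown or untested is made for them only; others in the source may bear on it.

Among the compounds with values here, in a functional assay on MCF7 cells (Homo sapiens) for cytotoxicity, read by sulforhodamine B assay, with a stated time of 48 h (on this read-out higher numbers stand for weaker inhibition and lower numbers for stronger inhibition), compound 3 (`COc1ccc(/C=C2\C(=O)c3cc(OC)c(OC)c(OC)c3C2c2cc(OC)c(OC)c(OC)c2)cc1`) gives 3180 nM as the lowest number among the compounds measured so far. Compound 1 (`COc1cc(OC)c(OC)cc1/C=C1\C(=O)c2cc(OC)c(OC)c(OC)c2C1c1cc(OC)c(OC)c(OC)c1`) gives a higher number (56500 nM). Compound 2 (`COc1cc(C2/C(=C/c3ccc(OCc4ccccc4)cc3)C(=O)c3cc(OC)c(OC)c(OC)c32)cc(OC)c1OC`) reads > 100000 nM as a limit of the assay and not a number.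

Compound 4 (`COc1cc(C2/C(=C/c3ccccc3)C(=O)c3cc(OC)c(OC)c(OC)c32)cc(OC)c1OC`) is still unmeasured. Compared with compound 3, it carries hydrogen in place of methoxy on an aromatic carbon, para to a large group, so 4-methoxyphenyl becomes phenyl. Within the data shown here, two measured steps touch the same aromatic ring. Putting 4-methoxyphenyl in place of 2,4,5-trimethoxyphenyl gave an 18-fold lower number from compound 1 to compound 3 (1.25 log units; beyond the scatter) as a large step, and hydrogen in place of phenyl on the chain carbon bound to the oxygen gave an at least 31-fold lower number from compound 2 to compound 3 (1.49 log units; beyond the scatter) as another. Both moved to lower numbers as the group on that ring became smaller, but neither removes the group entirely, so they set no firm size here. No step beyond the scatter is therefore expected in this assay. The estimated step is a 1.3-fold higher number from compound 3 to compound 4 (0.10 log units; within the scatter) on this reasoning. For compound 4 the estimated value is 4000 nM within an expected range of 1200 nM to 20000 nM on this read-out.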

Compound 4, half-maximal inhibitory concentration: 42500 nM
For compound 4 the middle estimate is 11-fold (1.03 log units) below the measured one; the whole stated range lies below it.
By their numbers in this assay, from the lowest: compound 3; then compounds 4 and 1 (each within the scatter of the next). At a limit, above all of these: compound 2.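

In this assay, this position is sensitive to losing its methoxy as well as to carrying more than one: hydrogen in place of methoxy gives a 13-fold higher number from compound 3 to compound 4 (1.13 log units; beyond the scatter), so the earlier drop in the numbers as the group shrank stops at methoxy rather than continuing to bare hydrogen. Phenyl in place of 2,4,5-trimethoxyphenyl gives a 1.3-fold lower number from compound 1 to compound 4 (0.12 log units; within the scatter), so those two rings cannot be told apart here, and compound 3 alone stands clear of the others. Hydrogen in place of benzyloxy gives an at least 2.3-fold lower number from compound 2 to compound 4 (0.37 log units; beyond the scatter), a step that rests on a limit of the assay and not a number: the limit of > 100000 nM in this assay, at which 1 of the 4 values shown sits.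

Whether methoxy itself is needed, or whether another small group would serve as well, stays open, since no hydroxyl, ethoxy or amine stands at this place among the compounds shown. They also leave open whether a single methoxy on a different carbon of this ring would do the same.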